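Removing the second chloro from a dichlorinated core

The source may report more compounds than this note shows. Statements on the series, on what has been measured and on what is new or still open speak of the compounds shown alone.

Measured so far:
Compound 1, `Nc1nc(Cl)c2ncn(Cc3ccccc3CCl)c2n1`: 3890 nM
Compound 2, `ClCc1ccccc1Cn1cnc2ncnc(Cl)c21`: 2750 nM
Compound 3, `ClCc1ccccc1Cn1cnc2c(Cl)nc(Cl)nc21`: 1230 nM

In a functional assay on OVCAR-8 cells (Homo sapiens) for cytotoxicity, read by sulforhodamine B assay, with a stated time of 48 h (a higher number here means a weaker inhibitor of growth, a lower number a stronger inhibitor of growth), compound 3 gives the lowest of the three numbers. Its nearest neighbour is compound 2, whose value of 2750 nM lies beyond the scatter above it, and the gap to compound 1 is wider still. Among the measured compounds shown here, the only single-point step among the measured compounds is a 3.2-fold lower number from compound 1 to compound 3 (0.50 log units; beyond the scatter), which shows that exchanging an amino group for a chloro group moved the number downward by a modest amount.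

Compound 4, `ClCc1ccccc1Cn1cnc2c(Cl)ncnc21`, differs from compound 3 by hydrogen in place of chloro on an aromatic carbon. For the measured compounds named here, no measured step shows this exact exchange, so the expectation rests on the observation that the two chloro-bearing compounds sit near each other, compound 2 giving 2750 nM while compound 3 gives 1230 nM, and that removing a heavy atom has no measured precedent here. Compound 4 is therefore expected to give a somewhat higher number than compound 3, with a step of a 1.8-fold higher number from compound 3 to compound 4 (0.25 log units; within the scatter), and an estimate of 2200 nM with a likely range from 1000 nM to 5000 nM.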

Compound 4, concentration for 50% growth inhibition: 2240 nM
For compound 4 the middle estimate is 1.0-fold (0.01 log units) below the measured one; low and high end bracket the measured number.
By their numbers in this assay, from the lowest: compounds 3, 4, 2 and 1 (each within the scatter of the next, the first and the last beyond it).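

In this assay, putting hydrogen in place of the chloro group between two ring nitrogen atoms gives a 1.8-fold higher number from compound 3 to compound 4 (0.26 log units; within the scatter), so losing this chloro produces no change that can be told from the scatter. With amino at the same position, the comparison gives a 1.7-fold lower number from compound 1 to compound 4 (0.24 log units; within the scatter), so hydrogen and amino cannot be told apart here either. Hydrogen therefore sits within the scatter of both chloro and amino, even though those two groups differ from each other beyond it, and the position so far shows only a modest spread across these three groups.

On these data alone, whether a methoxy group or a longer amine at this position would stand clearly apart from these three remains open. No supporting measurement is available to explain these results.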